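The source may hold more compounds than are shown below. What is called first, only, known or untested is meant among the compounds shown, and "the series" means these compounds.

Of the compounds shown here, three of one shared core have been tested in an assay on a protein complex for inhibition of CDK8/Cyclin C (Homo sapiens), with a stated time of 1 h; on this read-out higher numbers stand for weaker inhibition and lower numbers for stronger inhibition. Compound 1, `O=C(/C=C/c1ccncc1-c1ccc2[nH]ccc2c1)N1CCOCC1`, gives 190 nM. Compound 2, `O=C(/C=C/c1ccncc1-c1ccc2ccccc2c1)NC1CC1`, gives 40.1 nM. Compound 3, `O=C(/C=C/c1ccncc1-c1ccc2cc[nH]c2c1)N1CCOCC1`, gives 43.9 nM. Among these numbers compound 2 stands lowest, but its gap to compound 3 lies within the scatter of the measurement, so the two cannot be told apart; only compound 1 stands clearly higher, that is, weaker, than compound 2.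

The step considered here leads from compound 2 to compound 4, `CN(C)C(=O)/C=C/c1ccncc1-c1ccc2ccccc2c1`, which has not yet been measured. The change is dimethylamino in place of cyclopropylamino on a carbonyl carbon, so the amide nitrogen no longer carries a hydrogen. Going by the values given here, no measured pair in this set shows this change, so its size is unknown. Because compound 2 gives 40.1 nM, compound 4 is expected to stay close to that, with at most a modest weakening, a step of a 1.5-fold higher number from compound 2 to compound 4 (0.18 log units; within the scatter). In this assay compound 4 is thus estimated at 60 nM, within a range from 20 nM to 180 nM.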

Compound 4, half-maximal inhibitory concentration: 30.1 nM
Beside the measured number, compound 4's estimate is 2.0-fold (0.30 log units) above it, within the range that was stated.
By their numbers in this assay, from the lowest: compounds 4, 2 and 3 (each within the scatter of the next); then compound 1.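

In this assay, going by these compounds alone, this is the first pair that differs only at this position, and putting dimethylamino in place of cyclopropylamino on the carbonyl carbon gives a 1.3-fold lower number from compound 2 to compound 4 (0.12 log units; within the scatter). The change removes both the three-membered ring and the amide hydrogen, yet the read-out stays within the scatter, so this pair shows no need for either feature in this assay. Nothing available explains this result.

The compounds shown leave open whether methylamino, which would keep the amide hydrogen, or diethylamino, with its longer chains, would read the same on this carbonyl carbon. They also leave open whether the swap from cyclopropylamino to dimethylamino would behave the same way on the core of compound 3.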